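Adding a Second Chlorine to a Benzyl-Linked Purine-Like Core

A few compounds are considered here, and "the series" means these few. Any claim that something is new, unique, unknown or untested is made for them only; others in the source may bear on it.

Three compounds share a chloromethyl-benzyl group attached to a chlorinated fused two-ring core. Compound 1 `ClCc1ccccc1Cn1cnc2c(Cl)ncnc21` and compound 2 `ClCc1cccc(Cn2cnc3c(Cl)ncnc32)c1` differ only in where the chloromethyl arm sits on the benzene ring, and compound 3 `ClCc1ccc(Cn2cnc3nc(Cl)nc(Cl)c32)cc1` carries a further chloro on its core. In a functional assay on SK-MEL-28 cells (Homo sapiens) for cytotoxicity, read by sulforhodamine B assay, with a stated time of 48 h (a lower number here means a stronger inhibitor of growth, a higher number a weaker inhibitor of growth), compound 1 gives 2290 nM, compound 2 gives 2230 nM, and compound 3 gives 2180 nM. Compound 2 therefore sits within the scatter of both neighbours, so no ordering among the three can be claimed.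

Compound 4 `ClCc1cccc(Cn2cnc3c(Cl)nc(Cl)nc32)c1` is compound 2 with chloro in place of hydrogen on an aromatic carbon. Since compound 3 already shows that such a core chloro leaves the number unchanged within the scatter, the step from compound 2 to compound 4 is expected to be a 1.0-fold lower number from compound 2 to compound 4 (0.01 log units; within the scatter), essentially none. For compound 4 the estimate in this assay is 2200 nM, with a likely range from 1100 nM to 4500 nM.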

Compound 4, concentration for 50% growth inhibition: 2340 nM
Compound 4: the middle estimate sits 1.1-fold (0.03 log units) below what was measured; measured number inside the range.
By their numbers in this assay, from the lowest: compounds 3, 2, 1 and 4 (each within the scatter of the next).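

Placing chloro in place of hydrogen on this aromatic carbon, between two ring nitrogen atoms, gives a 1.0-fold higher number from compound 2 to compound 4 (0.02 log units; within the scatter) in this assay. Compounds 2 and 4 are the only pair shown that differ by this one change, so the chloro's lack of effect on the number is now seen directly rather than inferred. Nothing available explains this result. Still open, as far as these compounds go, is whether an amine or a methoxy group on this same carbon would shift the number. Also open, from the compounds shown here alone, is whether a plain methyl in place of the chloromethyl arm would do so.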